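Calpain-2 inhibition: ketoamide to ketoacid at the chain end

The source may report more compounds than this note shows. Statements on the series, on what has been measured and on what is new or still open speak of the compounds shown alone.

Measured compounds:
compound 1 `CCCCCCCCNC(=O)C(=O)C(CC)NC(=O)C(CC(C)C)NC(=O)OCc1ccccc1` 19 nM
compound 2 `CCC(NC(=O)C(CC(C)C)NC(=O)OCc1ccccc1)C(=O)C(=O)NCCCc1ccccc1` 43 nM

Both compounds share the same core and differ only in the group on the terminal amide nitrogen. In an assay on isolated protein (Oryctolagus cuniculus) for inhibition of Calpain-2 catalytic subunit (Homo sapiens), at pH 8.0 (a higher number here means a weaker inhibitor, a lower number a stronger inhibitor), compound 1 gives 19 nM and compound 2 gives 43 nM. Compound 2 stands at the higher number of the two; the step of a 2.3-fold higher number from compound 1 to compound 2 (0.35 log units; beyond the scatter) is modest but beyond the scatter.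

Compound 3 `CCC(NC(=O)C(CC(C)C)NC(=O)OCc1ccccc1)C(=O)C(=O)O` has not been measured. It differs from compound 2 by hydroxy in place of (3-phenylpropyl)amino on a carbonyl carbon; cut one bond further out, the change reads (3-phenylpropyl)carbamoyl to carboxy. Going by the values given here, no measured pair shows this kind of change: the only step on record, a 2.3-fold higher number from compound 1 to compound 2 (0.35 log units; beyond the scatter), swaps one chain substituent for another on the amide nitrogen and leaves the amide itself intact. Among the compounds with values here, it tells only that the group on that nitrogen matters somewhat. Removing the whole (3-phenylpropyl)amino group is a larger change than anything measured, so a weakening is expected, with wide uncertainty. Compound 3 is estimated at 90 nM (range 15 nM to 600 nM), meaning an expected step of a 2.1-fold higher number from compound 2 to compound 3 (0.32 log units; beyond the scatter).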

Compound 3, inhibition constant: 22 nM
For compound 3 the middle estimate is 4.1-fold (0.61 log units) above the measured one; the range from low to high includes it.
By their numbers in this assay, from the lowest: compounds 1, 3 and 2 (each within the scatter of the next, the first and the last beyond it).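

Putting hydroxy in place of (3-phenylpropyl)amino on a carbonyl carbon gives a 2.0-fold lower number from compound 2 to compound 3 (0.29 log units; within the scatter) in this assay, and putting hydroxy in place of octylamino gives a 1.2-fold higher number from compound 1 to compound 3 (0.06 log units; within the scatter). The earlier step showed only that exchanging one chain on the amide nitrogen for another shifts the number; these two steps show that the carboxy compound, which has neither chain and no amide at this position, stays within the scatter of both amides, so neither the octyl nor the 3-phenylpropyl chain is required for inhibition at this level in this series. No measurement at hand bears on why the amide and the carboxylic acid read alike.

Open, from the compounds shown here alone, is whether a primary amide or a methyl ester at this carbonyl carbon also stays in the same range, which would separate the effect of losing the chain from that of exchanging the amide for the carboxylic acid. Also open, going by these compounds, is whether a short chain such as methyl or ethyl on the amide nitrogen falls in line with compound 1 or with compound 2 .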